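Chloro in Place of Hydrogen on the Phenyl Ring

A few compounds are considered here, and "the series" means these few. Any claim that something is new, unique, unknown or untested is made for them only; others in the source may bear on it.

Measured in a functional assay, read by Griess assay, with a stated time of 150 min, tested at 100 ug/mL (on this read-out higher numbers stand for a stronger effect at the one concentration tested and lower numbers for a weaker effect), so far:
Compound 1, `O=S(=O)(CC1=NCCS1)c1n[nH]cc1-c1ccccc1`, gives "not active" (no number reported).
Compound 2, `O=S(=O)(CC1=NCCO1)C1C(c2ccc(Cl)cc2)=NN(c2ccccc2)C1c1ccc(Cl)cc1`, gives "not active" (no number reported).
Compound 3, `O=S(=O)(CC1=NCCO1)c1n[nH]cc1-c1ccccc1`, gives 57.5%.

Compound 3 is the only one of the three with a number in this assay; compound 1 and compound 2 are reported without one. Within the data shown here, compound 1 and compound 3 share the same core and differ only in the small ring attached through the sulfonyl group, yet one is reported without a number and the other with a clear value; no single step between them is laid out, so their two results can only be set side by side.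

Compound 4, `O=S(=O)(CC1=NCCO1)c1n[nH]cc1-c1ccc(Cl)cc1`, is the next compound to be measured in this assay. It differs from compound 3 by chloro in place of hydrogen on an aromatic carbon, at the position para to a large group on the six-membered ring of carbon only. Among the measured compounds shown here, with no measured step of this kind available, the change from compound 3 to compound 4 is expected to be small, with no clear direction beyond the usual scatter: the step of a number 2.5 percentage points lower from compound 3 to compound 4 (within the scatter) is my estimate. Compound 4 is therefore expected to give about 55% in this assay, with a likely range from 30% to 75%.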

Compound 4, a percentage reported as activity, at one concentration (the size of the read-out at that concentration, not a potency): "not active" (no number reported)
The entry for compound 4 holds no number; the estimate stays without a comparison.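

Compound 4 is reported without a number, so no step can be read from compound 3 to compound 4. The compounds shown leave open how large any effect of chloro in place of hydrogen is in this assay. No measured evidence bears on this result.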